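A Methoxy Group Added to Compound 3

The compounds below may be only part of what the source reports. "The series", "measured", "known", "first", "only" and "open" are said of these compounds alone.

- Compound 1 `COc1ccc(-c2nc3sc(-c4ccccc4)cn3n2)cc1`: 21%
- Compound 2 `C/C(=N/O)c1ccc(NC(=O)Cn2nc(C(F)(F)F)nc2N)cc1`: 4.65%
- Compound 3 `Clc1ccc(-c2cn3nc(-c4ccccc4)nc3s2)cc1`: 10%

All three compounds were tested in a functional assay on RPMI-8226 cells (Homo sapiens) for inhibition, read by sulforhodamine B assay, with a stated time of 48 h, tested at 10 uM (on this read-out lower numbers stand for less inhibition of growth and higher numbers for more inhibition of growth at the one concentration tested), and none of them comes close to stopping growth completely. In this test compound 3 gives 10%. Within the data shown here, that number lies within the usual scatter of the one for compound 2, so the two cannot be told apart. Compound 1 stands higher than compound 3, and that gap lies beyond the scatter.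

The next compound to be measured is compound 4 `COc1ccc(-c2nc3sc(-c4ccc(Cl)cc4)cn3n2)cc1`. It is compound 3 with methoxy in place of hydrogen on an aromatic carbon, para to a large group (methoxy in place of hydrogen on an aromatic carbon).

Among the measured compounds shown here, no measured pair shows this exact change on its own, so any forecast rests on thin evidence. The closest guide is compound 1, which also carries a methoxy group and gives 21%. A small rise in this assay is therefore expected, one that may well stay within the scatter. The estimated change is a number 7 percentage points higher from compound 3 to compound 4 (within the scatter). For compound 4 the expected value is 17%, with an estimated range from 5% to 36%.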

Compound 4, percent growth inhibition at one concentration: 55.1%
The estimate for compound 4 lay 38.1 percentage points below the measured number; the whole stated range lies below it.
By their numbers in this assay, from the lowest: compounds 2 and 3 (each within the scatter of the next); then compound 1; then compound 4.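

In this assay the methoxy group, placed on an aromatic carbon of a six-membered aromatic ring of carbon only and para to a large group, gives a number 45.1 percentage points higher from compound 3 to compound 4 (beyond the scatter) and so turns a weak compound into one with a clear effect on growth. Among these compounds, the chloro group, in place of hydrogen on an aromatic carbon, also matters on the same core, with a number 34.1 percentage points higher from compound 1 to compound 4 (beyond the scatter) and thus each of the two groups brings a large step when the other is already present, something no earlier compound could show. Nothing measured here explains why these steps are so large.

The compounds shown do not tell how large each step would be without the other group, so it remains open whether the gain from methoxy depends on the chloro group. From the compounds shown here alone, it is also open whether an ethoxy group, a hydroxyl group or an amine at the same place would give a similar rise, or whether the rise belongs to methoxy alone.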